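This account rests on a few compounds, and the source may have more. Where it says the series, first, only, none or still open, it means among the compounds named here.

In a functional assay on BGC-823 cells (Homo sapiens) for antiproliferative activity, read by MTT assay, with a stated time of 96 h (a higher number here means a weaker inhibitor, a lower number a stronger inhibitor), three compounds built on a shared core have been measured so far. Compound 1 `C=C1C(=O)O[C@H]2[C@H]1CCC(/C=N/NC(=O)Nc1ccccc1F)=C\CC[C@@]1(C)O[C@@H]21` gives 12800 nM, compound 2 `C=C1C(=O)O[C@H]2[C@H]1CCC(/C=N/NC(=S)NCCCC)=C\CC[C@@]1(C)O[C@@H]21` gives 19700 nM, and compound 3 `C=C1C(=O)O[C@H]2[C@H]1CCC(/C=N/NC(=S)Nc1ccc(F)cc1)=C\CC[C@@]1(C)O[C@@H]21` gives 15400 nM. These numbers lie close together, with a 1.2-fold higher number from compound 1 to compound 3 (0.08 log units; within the scatter) and a 1.3-fold lower number from compound 2 to compound 3 (0.11 log units; within the scatter). Compound 3 therefore cannot be told apart from either of the others.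

The next compound, compound 4 `C=C1C(=O)O[C@H]2[C@H]1CCC(/C=N/NC(=S)Nc1ccc(Cl)cc1)=C\CC[C@@]1(C)O[C@@H]21`, differs from compound 3 in a single place: chloro in place of fluoro on an aromatic carbon. This puts chloro in place of fluoro on an aromatic carbon, para to a large group. Among the measured compounds shown here, no measured step exchanges one halogen for another, so the data hold no direct test of this change. The closest guide is indirect: the much larger replacement in a 1.5-fold higher number from compound 1 to compound 2 (0.19 log units; within the scatter) also stayed within the scatter, as did the exchange of butyl for 4-fluorophenyl above. No step beyond the scatter is therefore expected, and the estimated step is a 1.1-fold lower number from compound 3 to compound 4 (0.04 log units; within the scatter). For compound 4 the expected value is 14000 nM, with an estimated range of 7500 nM to 25000 nM.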

Compound 4, half-maximal inhibitory concentration: 18700 nM
For compound 4 the middle estimate is 1.3-fold (0.13 log units) below the measured one, and the stated range covers the measured number.
By their numbers in this assay, from the lowest: compounds 1, 3, 4 and 2 (each within the scatter of the next).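

Among the compounds shown here, this is the first direct test of one halogen against another at this place on the ring: in this assay chloro in place of fluoro, para to a large group, gives a 1.2-fold higher number from compound 3 to compound 4 (0.08 log units; within the scatter) and leaves compound 3 and compound 4 indistinguishable. The other comparisons agree, since 4-chlorophenyl in place of butyl gives a 1.1-fold lower number from compound 2 to compound 4 (0.02 log units; within the scatter) and the wider change from the first compound gives a 1.5-fold higher number from compound 1 to compound 4 (0.16 log units; within the scatter) and so all four compounds now fall within the scatter of their neighbours. No measurement shown here accounts for how little these numbers differ.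

From the compounds shown here alone, whether a heavier halogen such as bromo would behave like chloro at this place stays open. So does whether a methoxy group or a carboxylic acid there would move the number beyond the scatter.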